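A few compounds are considered here, and "the series" means these few. Any claim that something is new, unique, unknown or untested is made for them only; others in the source may bear on it.

Measured so far in a functional assay on SW-620 cells (Homo sapiens) for antiproliferative activity, read by MTT assay, with a stated time of 72 h; a lower number here means a stronger inhibitor, a higher number a weaker inhibitor:
Compound 1 `CC(=O)OCC(CCn1cc(C#CC2CC2)c(=O)n(C(=O)c2ccccc2)c1=O)COC(C)=O` gives > 100000 nM, which is a limit of the assay.
Compound 2 `O=c1[nH]c(=O)n(CCC(CO)CO)cc1C#Cc1ccc(Br)cc1` gives > 100000 nM, likewise a limit.
Compound 3 `CCCCCc1ccc(C#Cc2cn(CCC(CO)CO)c(=O)[nH]c2=O)cc1` gives > 100000 nM, again a limit.

Compound 2 therefore stands at the limit of this assay and nowhere else: no number places it relative to any other compound. Among the compounds with values here, the one measured step that starts from it, a step that the two limits leave unreadable from compound 2 to compound 3, cannot be read in size or direction because both of its ends sit at the limit of > 100000 nM in this assay, at which 3 of the 3 values shown sit.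

Compound 4 `CC(C)(C)C#Cc1cn(CCC(CO)CO)c(=O)[nH]c1=O` differs from compound 2 in one place: tert-butyl in place of 4-bromophenyl on a triple-bonded carbon. Within the data shown here, the only measured step that bears on it is the one from compound 2 to compound 3, also a change at the group carried by the triple-bonded carbon, and it is unreadable; no other step has been measured at all. Among the measured compounds shown here, the evidence gives no size and no direction for a step in this assay and leaves open whether the change crosses the scatter.

Compound 4 is estimated to lie around 100000 nM, between 20000 nM and 500000 nM, with a further limit the most likely outcome. The estimated step from compound 2 is thus a number no higher from compound 2 to compound 4 (the limit leaves the size open).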

Compound 4, half-maximal inhibitory concentration: > 100000 nM
Compound 4 was reported as a limit (the forecaster's own chance of this, stated with the estimate: 85%); the middle value sits exactly at the limit.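

In this assay no new step can be read, since compound 2 and compound 4 both stand at a limit, so tert-butyl in place of 4-bromophenyl on a triple-bonded carbon has neither size nor direction. The compounds shown leave open whether any group at that place would give a number rather than a limit: the limit of > 100000 nM in this assay, at which 4 of the 4 values shown sit.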